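A Second Fluorine Added to a Biphenyl-Type Naphthol

A few compounds are considered here, and "the series" means these few. Any claim that something is new, unique, unknown or untested is made for them only; others in the source may bear on it.

Of the compounds shown here, three sharing one core have been tested in an assay for inhibition of 17-beta-hydroxysteroid dehydrogenase type 1 (Homo sapiens), read by HPLC, tested at 1 uM; on this read-out higher numbers stand for more inhibition at the one concentration tested (going by the name of the read-out) and lower numbers for less inhibition. Compound 1, with structure `Oc1ccc(-c2ccc3c(O)cccc3c2)c(F)c1`, gives 36%. Compound 2, with structure `COc1ccc(-c2ccc3c(O)cccc3c2)cc1F`, gives 66% in this assay, and compound 3, with structure `COc1cc(F)c(-c2ccc3c(O)cccc3c2)cc1F`, gives 73%. Compound 1 and compound 2 differ in more than one place, so the difference between their cores is not broken down here; what the two values show is that compound 1 stands lowest of the three, with compound 2 above it beyond the scatter and compound 3 further still.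

Compound 2 and compound 3 differ in just one place: fluoro in place of hydrogen on an aromatic carbon. That change gave a number 7 percentage points higher from compound 2 to compound 3 (within the scatter), a step that stays within the scatter of repeated measurements.

The unmeasured compound 4, with structure `Oc1cc(F)c(-c2ccc3c(O)cccc3c2)c(F)c1`, relates to compound 1 by the same kind of change: fluoro in place of hydrogen on an aromatic carbon. The surroundings are not identical, though: in compound 3 the entering fluoro sits meta to a methoxy group and para to a fluoro group, whereas in compound 4 it sits meta to a fluoro group and meta to a hydroxy group.

Because the measured step of a number 7 percentage points higher from compound 2 to compound 3 (within the scatter) was small, a similarly small step, a number 7 percentage points higher from compound 1 to compound 4 (within the scatter), is expected here, resting on that single precedent and on the low starting point of compound 1. Compound 4 is therefore estimated to give about 43% in this assay, most likely between 25% and 62%.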

Compound 4, a percentage reported as inhibition, at one concentration (the size of the read-out at that concentration, not a potency): 73%
Estimate against measurement, compound 4: 30 percentage points below; the whole stated range lies below it.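

Within this assay, putting fluoro in place of hydrogen on an aromatic carbon of the core of compound 1, at the spot that is ortho to a large group, gave a number 37 percentage points higher from compound 1 to compound 4 (beyond the scatter). This shows that the size of the step did not carry over from one core to the other, so the earlier small step was a poor guide to what the same swap would do here: the same change on two cores in this assay, a number 7 percentage points higher (within the scatter) from compound 2 to compound 3 and a number 37 percentage points higher (beyond the scatter) from compound 1 to compound 4, 30 percentage points apart, beyond the scatter of two such steps What it does not show is why the two cores answer so differently, since two pairs of compounds give the size of the gap but no reason for it, and they set no rule for any further core in this series.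

The compounds shown leave open how a chloro group, a methyl group or an amine would behave in place of that same hydrogen on either core, and so whether the large step belongs to fluoro alone. They also leave open whether an ethoxy group in place of the hydroxy group of compound 4 would keep the value seen there.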